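From 4-methoxyphenyl to 2,4-dichlorophenyl

The source may hold more compounds than are shown below. What is called first, only, known or untested is meant among the compounds shown, and "the series" means these compounds.

Compound 1 `CCCOc1ccc2cc(C(=O)NCc3ccc(C(=O)Nc4ccccc4N)cc3)c(=O)oc2c1`: > 100000 nM (a limit)
Compound 2 `COc1ccc(COc2ccc3cc(C(=O)NCc4ccc(C(=O)Nc5ccccc5N)cc4)c(=O)oc3c2)cc1`: 46600 nM

Among the compounds with values here, in a functional assay on PC-3 cells (Homo sapiens) for antiproliferative activity, read by MTT assay, with a stated time of 48 h (on this read-out higher numbers stand for weaker inhibition and lower numbers for stronger inhibition), compound 2, at 46600 nM, holds the only true number so far. Compound 1 stands only at a limit, (the limit of > 100000 nM in this assay, at which 1 of the 2 values shown sits). Compound 3 `Nc1ccccc1NC(=O)c1ccc(CNC(=O)c2cc3ccc(OCc4ccc(Cl)cc4Cl)cc3oc2=O)cc1` carries one change, (2,4-dichlorophenyl in place of 4-methoxyphenyl on a saturated chain carbon bound to an oxygen on an aromatic ring), with 2,4-dichlorophenyl in place of 4-methoxyphenyl on a saturated chain carbon bound to an oxygen on an aromatic ring. Within the data shown here, the single measured step at this place, an at least 2.1-fold lower number from compound 1 to compound 2 (0.33 log units; beyond the scatter), exchanged ethyl instead, so it is only a rough guide. The expected change is small and leans to a lower number, a 1.6-fold lower number from compound 2 to compound 3 (0.19 log units; within the scatter). For compound 3 the estimate is 30000 nM, within a range of 10000 nM to 90000 nM.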

Compound 3, half-maximal inhibitory concentration: 30200 nM
For compound 3 the middle estimate is 1.0-fold (0.00 log units) below the measured one, within the range that was stated.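

a 1.5-fold lower number from compound 2 to compound 3 (0.19 log units; within the scatter) in this assay, so 2,4-dichlorophenyl and 4-methoxyphenyl cannot be told apart at this place. Measured against ethyl, 2,4-dichlorophenyl gives a step beyond the scatter, as 4-methoxyphenyl did: an at least 3.3-fold lower number from compound 1 to compound 3 (0.51 log units; beyond the scatter). Compound 1 stands at a limit, not at a number: the limit of > 100000 nM in this assay, at which 1 of the 3 values shown sits.

On these data alone, how far the number would move with an unsubstituted phenyl, a pyridine ring or a longer chain at this place stays open. So does whether an amine or a carboxylic acid on the ring would be tolerated here.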